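Moving the chlorine on the benzylsulfanyl arm

A few compounds are considered here, and "the series" means these few. Any claim that something is new, unique, unknown or untested is made for them only; others in the source may bear on it.

Four close relatives of one shared core are compared here. Compound 1 `CC1=C(C(=O)Nc2ccc(Br)cc2)C(c2ccc(Cl)cc2Cl)N=C(SCc2ccccc2Cl)N1` carries a 2-chlorobenzyl group on its sulfur, while compound 2 `CC1=C(C(=O)Nc2ccc(Br)cc2)C(c2ccc(Cl)cc2Cl)N=C(SCc2cccc(Cl)c2)N1` carries a 3-chlorobenzyl group in the same place; the difference between them is 3-chlorophenyl in place of 2-chlorophenyl on a saturated chain carbon bound to a sulfur. Both were tested in a functional assay on the whole organism (artery, strain albino) with Rattus norvegicus as the target, with a stated time of 600 min, at a dose of 10 mg/kg by the oral route; a higher number here means more inhibition at the dose given (going by the name of the read-out), a lower number less inhibition. In that test compound 1 gives 24.6%, and compound 2 gives 15.4%, so that a number 9.2 percentage points lower from compound 1 to compound 2 (within the scatter).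

Compound 3 `CC1=C(C(=O)Nc2ccc([N+](=O)[O-])cc2)C(c2cccc([N+](=O)[O-])c2)N=C(SCc2ccccc2Cl)N1` keeps the 2-chlorobenzyl group but sits on a different core; how its core differs from that of compound 1 is not broken down here. In this assay compound 3 gives 13.3%. Against compound 2 the gap is within the usual scatter of the test; against compound 1 it is beyond it.

Compound 4 `CC1=C(C(=O)Nc2ccc([N+](=O)[O-])cc2)C(c2cccc([N+](=O)[O-])c2)N=C(SCc2cccc(Cl)c2)N1` has not yet been measured. It relates to compound 3 as compound 2 relates to compound 1: the change is 3-chlorophenyl in place of 2-chlorophenyl on a saturated chain carbon bound to a sulfur, made at the same place as before, so it is the same change. The earlier pair moved only a little, and compound 3 starts from 13.3%, so only a modest downward move, if any, is expected: the step from compound 3 to compound 4 is estimated as a number 5.3 percentage points lower from compound 3 to compound 4 (within the scatter), resting on a number 9.2 percentage points lower from compound 1 to compound 2 (within the scatter). Accordingly compound 4 is expected to give about 8% in this assay, most likely between 0% and 20%.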

Compound 4, a percentage reported as inhibition, in the whole organism at one dose (the size of the read-out at that dose, not a potency): 19%
Beside the measured number, compound 4's estimate is 11 percentage points below it, within the range that was stated.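

In this assay, moving from the 2-chlorobenzyl to the 3-chlorobenzyl group gives a number 5.7 percentage points higher from compound 3 to compound 4 (within the scatter), so on this core the swap alone produces no clear change. Set beside the earlier pair, however, the same swap does not carry over from one core to the other as a fixed amount, and the two steps run in opposite directions: the same change on two cores in this assay, a number 9.2 percentage points lower (within the scatter) from compound 1 to compound 2 and a number 5.7 percentage points higher (within the scatter) from compound 3 to compound 4, 14.9 percentage points apart, beyond the scatter of two such steps This does not show why the cores respond differently: neither step on its own stands clear of the scatter, only the gap between them does, and two pairs cannot reveal which feature of the cores goes with that gap.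

The compounds shown leave open how the swap behaves on a core carrying a methoxy group or a carboxylic acid in place of the bromine or the nitro groups, which would indicate whether the two results seen so far are typical of the series. They also leave open what an unsubstituted benzyl group or a longer chain such as phenethyl on the sulfur would give, and so how much the chlorine contributes at all.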